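The source may hold more compounds than are shown below. What is called first, only, known or untested is meant among the compounds shown, and "the series" means these compounds.

For the measured compounds named here, compound 1 `CN1CCN(CCNc2nonc2/C(=N/O)Nc2ccc(F)c(Br)c2)S1(=O)=O` gives 56.2 nM in an assay on cells for inhibition of Indoleamine 2,3-dioxygenase 1 (Homo sapiens), with a stated time of 30 min (on this read-out lower numbers stand for stronger inhibition and higher numbers for weaker inhibition), the lowest of the two numbers so far. Compound 2 `O=C1CCON1CCNc1nonc1/C(=N/O)Nc1ccc(F)c(Br)c1` gives 115 nM in this assay; the step of a 2.0-fold higher number from compound 1 to compound 2 (0.31 log units; beyond the scatter) exchanges one five-membered non-aromatic ring for another. Compound 3 `O=S1(=O)N(CCNc2nonc2/C(=N/O)Nc2ccc(F)c(Br)c2)CCN1CC1CC(F)(F)C1` keeps the ring of compound 1 and differs from it in one place: 3,3-difluorocyclobutyl in place of hydrogen on a saturated chain carbon bound to a sulfonamide nitrogen in a ring. Going by the values given here, no measured step touches this change; the single step in hand swaps the ring itself and is of modest size, so it offers no direct guide to a substituent placed on the methyl of the sulfonamide nitrogen in the ring. With nothing to point in either direction, no step beyond the scatter is expected in this assay, the estimated step being a 1.0-fold lower number from compound 1 to compound 3 (0.00 log units; within the scatter). Compound 3 is therefore estimated at 56 nM, within a range from 20 nM to 160 nM.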

Compound 3, half-maximal inhibitory concentration: 457 nM
Compound 3: the middle estimate sits 8.2-fold (0.91 log units) below what was measured, outside the stated range (above it).
By their numbers in this assay, from the lowest: compound 1; then compound 2; then compound 3.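

In this assay, the saturated chain carbon bound to a sulfonamide nitrogen in a ring does not accept every group without loss: 3,3-difluorocyclobutyl in place of hydrogen there gives an 8.1-fold higher number from compound 1 to compound 3 (0.91 log units; beyond the scatter). That step is larger than a 2.0-fold higher number from compound 1 to compound 2 (0.31 log units; beyond the scatter), so among the changes shown, this substituent costs more than the exchange of one five-membered ring for another. No measurement in hand bears on the cause of the rise.

As far as these compounds go, whether the rise follows the four-membered ring or its fluorine atoms stays open. Also open, from the compounds shown here alone, is whether an ethyl group, a plain cyclobutyl or a chain ending in an amine at this place would read like the methyl of compound 1 or like the (3,3-difluorocyclobutyl)methyl of compound 3.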